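The compounds below may be only part of what the source reports. "The series", "measured", "known", "first", "only" and "open" are said of these compounds alone.

Compound 1, `C[C@H](Oc1cc2cc(F)ccc2nc1N)c1cc(F)c(F)cc1-n1cccn1`, gives 4.1.
Compound 2, `C[C@H](Oc1cc2ccccc2nc1N)c1cc(F)ccc1-n1cccn1`, gives 4.
Compound 3, `C[C@H](Oc1cc2cc(F)ccc2nc1N)c1cc2c(cnn2CCO)cc1-n1cccn1`, gives 3.3.

These three numbers come from a physicochemical assay for lipophilicity, using the shake flask method; on this read-out lower numbers stand for lower lipophilicity and higher numbers for higher lipophilicity. On this read-out compound 1 and compound 2 cannot be told apart, since the gap between them lies within the usual scatter. Compound 3 stands apart: its number lies beyond the scatter below that of compound 1, so of the three measured compounds only compound 3 is clearly less lipophilic than compound 1.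

Compound 4, `C[C@H](Oc1cc2cc(C#N)ccc2nc1N)c1cc(F)c(F)cc1-n1cccn1`, has not yet been measured in this assay. It differs from compound 1 in one place: cyano in place of fluoro on an aromatic carbon. Within the data shown here, no pair of measured compounds carries this same change, so there is no measured step to lean on; the expectation rests on the structural change alone.

Going from compound 1 to compound 4 a modest fall is expected, a step of about a number 0.60 log units lower from compound 1 to compound 4 (beyond the scatter), somewhat beyond the scatter rather than within it. Compound 4 is therefore estimated at 3.5, with a likely range from 3 to 4.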

Compound 4, distribution coefficient: 4.3
Beside the measured number, compound 4's estimate is 0.80 log units below it; the whole stated range lies below it.
By their numbers in this assay, from the lowest: compound 3; then compounds 2, 1 and 4 (each within the scatter of the next).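

In this assay the step is a number 0.20 log units higher from compound 1 to compound 4 (within the scatter) when cyano takes the place of fluoro on this aromatic carbon, so at this position the two groups cannot be told apart on this read-out. This is the first single-place step among the compounds shown, and it shows that a group with a triple bond and a hydrogen-bond acceptor can stand where fluoro stood with no measurable shift in the distribution coefficient. No measurement available here explains this result.

As far as these compounds go, this is one change in one pair, so it remains open whether the same swap would read the same on the core of compound 3. Also open, from the compounds shown here alone, is how an amine, a methoxy group or a carboxylic acid on this same aromatic carbon would read.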